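The source may hold more compounds than are shown below. What is called first, only, known or untested is meant among the compounds shown, and "the series" means these compounds.

Compound 1, `COC(=O)c1ccc(NCc2cncn2Cc2ccccc2)cc1-c1ccccc1`, gives > 1000 nM in a toxicity assay on NIH3T3 cells (Mus musculus) for cytotoxicity, read by resazurin assay; on this read-out higher numbers stand for an effect only at larger amounts of compound and lower numbers for an effect already at smaller amounts; this value is a limit of the assay, not a number.
Compound 2, `COC(=O)c1ccc(NCc2cncn2Cc2cccc(C)c2)cc1-c1ccccc1`, gives > 10000 nM in this assay; this too is only a limit.
Compound 3, `c1ccc(Cn2cncc2CNc2cccc(-c3ccccc3)c2)cc1`, gives > 750 nM in this assay; again a limit rather than a number.

Compound 4, `Cc1ccc(Cn2cncc2CNc2cccc(-c3ccccc3)c2)cc1`, has not yet been measured in this assay. Its difference from compound 3 is methyl in place of hydrogen on an aromatic carbon. The same kind of change is already measured between compound 1 and compound 2: methyl in place of hydrogen on an aromatic carbon. The two places are not identical: in compound 2 the methyl stands meta to a large group, in compound 4 para to a large group. The cores of the two pairs differ as hydrogen in place of methoxycarbonyl on an aromatic carbon. The measured step that the two limits leave unreadable from compound 1 to compound 2 cannot be read, as the limits the limit of > 1000 nM in this assay, at which 1 of the 3 values shown sits, and the limit of > 10000 nM in this assay, at which 1 of the 3 values shown sits, show. With compound 3 itself sitting only at a limit (the limit of > 750 nM in this assay, at which 1 of the 3 values shown sits), the step is expected to be a step that the limit leaves unreadable from compound 3 to compound 4 and to remain unreadable in the same way. Compound 4 is therefore expected at 3000 nM, most likely reported as a limit only.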

Compound 4, half-maximal effective concentration: 10000 nM
Estimate against measurement, compound 4: 3.3-fold (0.52 log units) below; the range from low to high includes it.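

No size can be given for the change from compound 3 to compound 4, because compound 3 is known only as a limit, not as a number: the limit of > 750 nM in this assay, at which 1 of the 4 values shown sits.

The compounds shown leave open whether, with or without the methoxycarbonyl, a methyl on the aromatic ring changes the amount of compound needed for an effect in this assay at all.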